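Solubility: from the acid of compound 2 to its amide

The compounds below may be only part of what the source reports. "The series", "measured", "known", "first", "only" and "open" are said of these compounds alone.

Measured compounds:
compound 1 `CCCCCCCc1[nH]c2ccc([N+](=O)[O-])cc2c(=O)c1C(=O)OCC`: 5000 nM
compound 2 `CCCCCCCc1[nH]c2ccc([N+](=O)[O-])cc2c(=O)c1C(=O)O`: 15000 nM

Two compounds share one core and differ only at the group on the carbonyl carbon. In a physicochemical assay for solubility, read by HPLC, at pH 7.4 (on this read-out lower numbers stand for lower solubility and higher numbers for higher solubility), compound 1 gives 5000 nM, and compound 2 gives 15000 nM. Compound 2 holds the higher of the two numbers, by a 3.0-fold higher number from compound 1 to compound 2 (0.48 log units; beyond the scatter).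

Compound 3 `CCCCCCCc1[nH]c2ccc([N+](=O)[O-])cc2c(=O)c1C(N)=O` has not been measured. It differs from compound 2 by amino in place of hydroxy on a carbonyl carbon. Going by the values given here, the one measured step, a 3.0-fold higher number from compound 1 to compound 2 (0.48 log units; beyond the scatter), also changed the group on that carbonyl carbon, but it swapped ethyl for hydrogen on an oxygen, not amino for hydroxy, so it offers only a loose guide. Among the compounds with values here, no measured pair shows the present change.

Without a matching step, the expectation leans on the nearby compound 1. Compound 3 is expected to sit near compound 1, that is a step of a 3.0-fold lower number from compound 2 to compound 3 (0.48 log units; beyond the scatter), giving an estimated 5000 nM with a range from 1500 nM to 17000 nM.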

Compound 3, solubility: 15000 nM
Beside the measured number, compound 3's estimate is 3.0-fold (0.48 log units) below it; the measured number falls inside the stated range.
By their numbers in this assay, from the lowest: compound 1; then compounds 2 and 3 (each within the scatter of the next).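

In this assay, putting amino in place of hydroxy on the carbonyl carbon gives no change at the digits printed from compound 2 to compound 3 (within the scatter), so on this read-out the carboxy and carbamoyl groups cannot be told apart at this position. Changing ethoxy to amino at the same carbon gives a 3.0-fold higher number from compound 1 to compound 3 (0.48 log units; beyond the scatter), which matches the size of the earlier step from ethyl to hydrogen on the oxygen; of the three groups now seen here, only the ethoxy group goes with the lower number. Nothing at hand explains this result.

From the compounds shown here alone, it remains open whether the number would hold with a larger group on the amide nitrogen, such as methylamino or dimethylamino. The compounds shown also leave open how a shorter chain in place of the long chain on the shared core would change the picture.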